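The source may hold more compounds than are shown below. What is called first, only, known or untested is meant among the compounds shown, and "the series" means these compounds.

In a functional assay on HEK293 cells for negative allosteric modulation of metabotropic glutamate receptor 5 (Homo sapiens), read by calcium flux, with a stated time of 20 min (on this read-out higher numbers stand for weaker inhibition and lower numbers for stronger inhibition), compound 1 `O=C(c1ccccc1)N1CCn2nc(-c3ccncc3)cc2C1` gives 1290 nM, while compound 2 `O=C(c1ccccc1)N1CCn2nc(-c3ccc(F)cn3)cc2C1` gives 164 nM. Of the two numbers shown, compound 2 stands lowest; the only measured step, a 7.9-fold lower number from compound 1 to compound 2 (0.90 log units; beyond the scatter), was a change of the aryl group on the shared core. Compound 3 `O=C(c1cccc(F)c1)N1CCn2nc(-c3ccc(F)cn3)cc2C1` differs from compound 2 at another place: fluoro in place of hydrogen on an aromatic carbon. Among the measured compounds shown here, nothing among the measured steps touches the benzoyl ring, so no measured step bears directly on this change, and the one step available, concerning a different ring, offers no guide to its size or direction. The expectation for compound 3 is therefore a step no larger than the scatter, a 1.3-fold lower number from compound 2 to compound 3 (0.10 log units; within the scatter), with no confident direction. Compound 3 is accordingly estimated at 130 nM in this assay, within a range from 40 nM to 420 nM.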

Compound 3, half-maximal inhibitory concentration: 257 nM
Beside the measured number, compound 3's estimate is 2.0-fold (0.30 log units) below it; low and high end bracket the measured number.
By their numbers in this assay, from the lowest: compounds 2 and 3 (each within the scatter of the next); then compound 1.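

In this assay, among the compounds shown here, the change from phenyl to 3-fluorophenyl gives a 1.6-fold higher number from compound 2 to compound 3 (0.20 log units; within the scatter) and is the first measured step at this ring, which stayed unsubstituted in the earlier compounds. For the compounds shown here, it shows that this fluoro, on an aromatic carbon meta to a large group, leaves the number indistinguishable from that of compound 2, whereas the only earlier step, at the other aryl group, lay beyond the scatter. No supporting measurement is available to explain this result.

On these data alone, whether a different group at this same place, such as chloro, methoxy, a nitrile or an amine, would give a step beyond the scatter remains open. Also open, as far as these compounds go, is whether fluoro on another carbon of this ring would behave as this one does, or whether this result would carry over with pyridin-4-yl on the shared core.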